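The source may report more compounds than this note shows. Statements on the series, on what has been measured and on what is new or still open speak of the compounds shown alone.

Compound 1, `CCCCCOC1=C(C(=O)c2ccccc2)C(c2ccc(Br)cc2)N(CCCn2ccnc2)C1=O`: 9140 nM
Compound 2, `O=C(C1=C(OC2CCCCC2)C(=O)N(CCCn2ccnc2)C1c1ccc(Br)cc1)c1ccccc1`: 22400 nM
Compound 3, `CCOc1ccc(NC2=C(C(=O)c3ccccc3)C(c3ccc(Br)cc3)N(CCCn3ccnc3)C2=O)cc1`: 26200 nM

In a functional assay on U2OS cells (Homo sapiens) for antiproliferative activity, read by MTT assay, with a stated time of 72 h (a higher number here means a weaker inhibitor, a lower number a stronger inhibitor), compound 2 gives 22400 nM, the second highest of the three numbers. Its nearest neighbour is compound 3 with 26200 nM, and the step between them, a 1.2-fold higher number from compound 2 to compound 3 (0.07 log units; within the scatter), lies within the scatter. Its furthest neighbour is compound 1 with 9140 nM, and the step of a 2.5-fold higher number from compound 1 to compound 2 (0.39 log units; beyond the scatter) lies beyond the scatter, as does a 2.9-fold higher number from compound 1 to compound 3 (0.46 log units; beyond the scatter).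

Compound 4, `O=C(C1=C(Nc2cccc(Br)c2)C(=O)N(CCCn2ccnc2)C1c1ccc(Br)cc1)c1ccccc1`, is the next compound to be measured. It differs from compound 2 in one place: (3-bromophenyl)amino in place of cyclohexyloxy on a double-bonded ring carbon. Among the compounds with values here, the step that bears on this is the one from compound 2 to compound 3, where an arylamino group likewise replaced the cyclohexyloxy group on the same ring carbon, and that step, a 1.2-fold higher number from compound 2 to compound 3 (0.07 log units; within the scatter), stayed within the scatter. On this single precedent no step beyond the scatter is expected in this assay for compound 4, though the direction, if any, would be towards a higher number. Compound 4 is therefore estimated at 25000 nM, within a range of 10000 nM to 60000 nM, which means an expected step of a 1.1-fold higher number from compound 2 to compound 4 (0.05 log units; within the scatter).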

Compound 4, half-maximal inhibitory concentration: 11900 nM
The estimate for compound 4 lay 2.1-fold (0.32 log units) above the measured number; the measured number falls inside the stated range.
By their numbers in this assay, from the lowest: compounds 1, 4, 2 and 3 (each within the scatter of the next, the first and the last beyond it).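

Within the arylamino pair in this assay, the group on the amine nitrogen matters: 3-bromophenyl in place of 4-ethoxyphenyl gives a step beyond the scatter (a 2.2-fold lower number from compound 3 to compound 4 (0.34 log units; beyond the scatter)). The change from an oxygen to a nitrogen link at this double-bonded ring carbon therefore does not fix the number by itself. Compound 4 stays within the scatter of both ethers (a 1.9-fold lower number from compound 2 to compound 4 (0.27 log units; within the scatter); a 1.3-fold higher number from compound 1 to compound 4 (0.11 log units; within the scatter)), whereas the earlier arylamino compound differed from the pentyl ether by more than the scatter.

Nothing given here accounts for these steps. The compounds leave open whether the step within the arylamino pair follows from the bromine or from where the substituent stands, which a 4-bromophenylamino group would separate, and how an unsubstituted phenylamino or a cyclohexylamino group would read here.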